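Shortening the basic side chain of compound 2

A few compounds are considered here, and "the series" means these few. Any claim that something is new, unique, unknown or untested is made for them only; others in the source may bear on it.

Three members of the series have numbers in a functional assay on A549 cells (Homo sapiens) for antiproliferative activity, read by MTT assay, with a stated time of 48 h; a lower number here means a stronger inhibitor, a higher number a weaker inhibitor. Compound 1 `CN1CCN(CCCCOc2c(O)cc3oc(-c4ccccc4)cc(=O)c3c2O)CC1` sits at a limit of the assay: in this assay compound 1 gives > 100000 nM, which is a limit and not a number (the limit of > 100000 nM in this assay, at which 1 of the 3 values shown sits). Compound 3 `COc1cc2oc(-c3ccccc3)cc(=O)c2c(O)c1OCCCN1CCN(C)CC1` gives 18000 nM in this assay. Compound 2 `CCN(CC)CCCCOc1c(OCc2ccccc2)cc2oc(-c3ccccc3)cc(=O)c2c1O` gives 1800 nM in this assay, the lowest of the two numbers shown; the gap to compound 3 lies beyond the scatter. No two of these compounds differ in one place only, so no single step can be read from them.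

Compound 4 `CN(C)CCCOc1c(OCc2ccccc2)cc2oc(-c3ccccc3)cc(=O)c2c1O` is not yet measured in this assay. It keeps the core and the benzyloxy group of compound 2 and differs in one place: dimethylamino in place of (diethylamino)methyl on a saturated chain carbon, three bonds along the chain from an oxygen on an aromatic ring. Within the data shown here, nothing among the measured compounds isolates this change, so the size of the step rests on compound 2 alone and on the general observation that such small changes to a basic chain seldom move this assay far. The expectation is a small step from compound 2 to compound 4, within or just beyond the scatter, of the size a 1.7-fold higher number from compound 2 to compound 4 (0.22 log units; within the scatter), if anything towards a weaker inhibitor. Compound 4 is therefore estimated at 3000 nM in this assay, with a range from 1000 nM to 10000 nM.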

Compound 4, half-maximal inhibitory concentration: 2600 nM
The estimate for compound 4 lay 1.2-fold (0.06 log units) above the measured number, within the range that was stated.
By their numbers in this assay, from the lowest: compounds 2 and 4 (each within the scatter of the next); then compound 3. At a limit, above all of these: compound 1.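

In this assay, among these compounds, compounds 2 and 4 form the first pair that differs in one place, so this position can now be read directly: with 3-(dimethylamino)propyl in place of 4-(diethylamino)butyl, the step is a 1.4-fold higher number from compound 2 to compound 4 (0.16 log units; within the scatter). The chain and its amine can therefore change together at this position without the reading leaving the scatter, and compounds 2 and 4 cannot be ranked against each other. This holds only for this pair with the benzyloxy group kept, and no measured property of the two groups bears on the step.

Because the chain length and the substituents on the nitrogen change together in this step, the pair cannot separate their contributions, and a 4-(dimethylamino)butyl or 3-(diethylamino)propyl chain on the same core would be needed to do so. From the compounds shown here alone, it also remains open whether a pyrrolidine or morpholine at the end of the chain, or a chain longer than 4-(diethylamino)butyl, would stay as close to compound 2.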